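Swapping the Amine Arm for an Amide

A few compounds are considered here, and "the series" means these few. Any claim that something is new, unique, unknown or untested is made for them only; others in the source may bear on it.

Compound 1 `CN(C)CC1CCCc2cc(S(=O)(=O)c3ccccc3)ccc21`: 0.0631 nM
Compound 2 `COCCNC[C@@H]1CCCc2cc(S(=O)(=O)c3cccc(F)c3)ccc21`: 0.251 nM

In an assay on isolated protein for displacement of a labelled ligand from 5-hydroxytryptamine receptor 6 (Homo sapiens) (a lower number here means a stronger inhibitor, a higher number a weaker inhibitor), compound 2 gives 0.251 nM, the highest of the two numbers shown, while compound 1 gives 0.0631 nM, a gap beyond the usual scatter. Compound 3 `CC(=O)N(C)C[C@@H]1CCCc2cc(S(=O)(=O)c3cccc(F)c3)ccc21` differs from compound 2 in one place: acetyl(methyl)amino in place of (2-methoxyethyl)amino on a saturated chain carbon bound to a saturated ring carbon. Among the compounds with values here, no measured pair shows a change of this kind, so the outcome rests on expectation alone. For compound 3 a move toward a higher number, well beyond the scatter, is expected: a 100-fold higher number from compound 2 to compound 3 (2.00 log units; beyond the scatter). Compound 3 is therefore estimated at 25 nM, within a range from 2 nM to 300 nM.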

Compound 3, inhibition constant: 1.59 nM
For compound 3 the middle estimate is 16-fold (1.20 log units) above the measured one, and the stated range ends above it.
By their numbers in this assay, from the lowest: compound 1; then compound 2; then compound 3.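

On the saturated chain carbon bound to a saturated ring carbon, this assay tolerates acetyl(methyl)amino in place of (2-methoxyethyl)amino with only a modest loss, a 6.3-fold higher number from compound 2 to compound 3 (0.80 log units; beyond the scatter). The arm keeps its 5 heavy atoms but goes from 1 hydrogen-bond donor to 0, and compound 3 still gives 1.59 nM. No measurement here explains this loss. On these data alone, it remains open whether the loss goes with the new carbonyl or with the missing donor. A methylamino arm or a propanoyl(methyl)amino arm at this place could help separate the two.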